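A Methyl on the Phenyl of Compound 3

The source may hold more compounds than are shown below. What is called first, only, known or untested is meant among the compounds shown, and "the series" means these compounds.

Compound 3 `O=c1[nH]cc(S(=O)(=O)Nc2cccc(-c3cn(-c4ccccc4)nn3)c2)c(=O)[nH]1` stands at the upper end of the numbers gathered so far: in a functional assay on SGC-7901 cells (Homo sapiens) for antiproliferative activity, read by MTT assay, with a stated time of 24 h (a lower number here means a stronger inhibitor, a higher number a weaker inhibitor), compound 3 gives 17200 nM. Its nearest neighbour, compound 1 `O=c1[nH]cc(S(=O)(=O)Nc2ccccc2-c2cn(-c3ccccc3)nn2)c(=O)[nH]1`, gives 11800 nM, a gap that lies within the scatter, so the two cannot be ordered against each other. Among the compounds with values here, compound 2 `O=c1[nH]cc(S(=O)(=O)Nc2ccccc2-c2cn(-c3cccc(Cl)c3)nn2)c(=O)[nH]1` gives 2270 nM, and the only single-point step measured so far, a 5.2-fold lower number from compound 1 to compound 2 (0.72 log units; beyond the scatter), came from a chloro in place of hydrogen on an aromatic carbon.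

Compound 4 `Cc1ccccc1-n1cc(-c2cccc(NS(=O)(=O)c3c[nH]c(=O)[nH]c3=O)c2)nn1` differs from compound 3 by methyl in place of hydrogen on an aromatic carbon, on an aromatic carbon of a six-membered aromatic ring of carbon only, ortho to a large group; cut one bond further out, the change reads phenyl to 2-methylphenyl. The step from compound 1 to compound 2 is the only one that bears on this change, and it concerns a different substituent at a different place on a differently connected scaffold. A modest lowering of the number is therefore expected, smaller than that step and not secure beyond the scatter. Compound 4 is expected to give 8000 nM, between 3000 nM and 25000 nM, which would be a step of a 2.2-fold lower number from compound 3 to compound 4 (0.33 log units; beyond the scatter).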

Compound 4, half-maximal inhibitory concentration: 9230 nM
Beside the measured number, compound 4's estimate is 1.2-fold (0.06 log units) below it; the range from low to high includes it.
By their numbers in this assay, from the lowest: compound 2; then compounds 4, 1 and 3 (each within the scatter of the next).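

In this assay, the change from phenyl to 2-methylphenyl is a 1.9-fold lower number from compound 3 to compound 4 (0.27 log units; within the scatter), so on the core of compound 3 a methyl ortho to a large group does not separate the two compounds. Within the data shown here, this is the first substituent seen on this phenyl ring of that core, and it shows that the ring carries a methyl here with no change that can be read beyond the scatter, whereas the only earlier step, a 5.2-fold lower number from compound 1 to compound 2 (0.72 log units; beyond the scatter), came from a chloro on the core of compound 1 and did lie beyond it. Nothing at hand offers any measurement that would account for this result.

The compounds shown leave open whether a chloro on the phenyl ring of compound 3 would repeat the step seen on the core of compound 1, and whether a methyl would behave on that other core as it does here. They also leave open what a different group at this same place, such as an amine, a carboxylic acid or a longer chain, would do to the number.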